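A few compounds are considered here, and "the series" means these few. Any claim that something is new, unique, unknown or untested is made for them only; others in the source may bear on it.

Measured so far:

Compound 1 `OC[C@H]1O[C@@H](n2cnc3c(Cl)nccc32)C[C@@H]1O`. In a functional assay on EL4 cells (Mus musculus) for inhibition, tested at 100 uM (a lower number here means less inhibition, a higher number more inhibition at the concentration tested (going by the name of the read-out)), compound 1 reaches only the limit < 5%, a limit of the assay rather than a number.
Compound 2 `OC[C@H]1O[C@@H](n2cnc3c(SCc4ccccc4)nccc32)C[C@@H]1O`. In this assay compound 2 gives 11%.
Compound 3 `OC[C@H]1OC(n2cnc3c(SCc4ccccc4)nccc32)[C@H](O)[C@@H]1O`. In this assay compound 3 gives 30%, the highest of the two numbers, beyond the scatter of compound 2.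

Compound 4 `OC[C@H]1OC(n2cnc3c(Cl)nccc32)[C@H](O)[C@@H]1O` has not yet been measured. The difference between the core of compound 2 and the core of compound 3 is not broken down here. The change from compound 2 to compound 1 is chloro in place of benzylsulfanyl on an aromatic carbon, and in this assay it gave a number at least 6 percentage points lower from compound 2 to compound 1 (that floor lies within the scatter); its true size is hidden by the limit of < 5% in this assay, at which 1 of the 3 values shown sits. The change from compound 3 to compound 4 is chloro in place of benzylsulfanyl on an aromatic carbon, the same change made on the other core. Since compound 3 starts higher, a drop of similar or larger size is expected, a number 20 percentage points lower from compound 3 to compound 4 (beyond the scatter), resting on the measured step from compound 2 to compound 1. Compound 4 is therefore expected to reach about 10%, between 2% and 22%.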

Compound 4, a percentage reported as inhibition, at one concentration (the size of the read-out at that concentration, not a potency): < 5%
Compound 4 gave a limit, no number; the forecaster's own chance of this, stated with the estimate: 30%; middle value at least 5 percentage points from the limit.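

In this assay, putting chloro in place of benzylsulfanyl on the core of compound 3 gives a number at least 25 percentage points lower from compound 3 to compound 4 (beyond the scatter). The same change on the core of compound 2 points the same way, but this does not show that the change carries over from one core to the other at equal size: the same change on two cores in this assay, a number at least 6 percentage points lower (that floor lies within the scatter) from compound 2 to compound 1 and a number at least 25 percentage points lower (beyond the scatter) from compound 3 to compound 4; the limit leaves it open whether they differ. Compound 4 gives < 5%, which is a limit of the assay and not a number, so the true size of both steps stays hidden: the limit of < 5% in this assay, at which 2 of the 4 values shown sit.

With only benzylsulfanyl and chloro at this aromatic carbon, the compounds shown leave open whether the benzene ring, the sulfur or both go with the higher readings. Also open, as far as these compounds go, is how other groups at the same carbon, such as a simple amine or a methylsulfanyl group, would fare on each core, and whether any of them would lift the inhibition clear of the limit.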